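A few compounds are considered here, and "the series" means these few. Any claim that something is new, unique, unknown or untested is made for them only; others in the source may bear on it.

Three compounds have been measured in an assay on isolated protein for inhibition of protein deacetylase HDAC6 (Homo sapiens); on this read-out higher numbers stand for weaker inhibition and lower numbers for stronger inhibition:

Compound 1 `O=C(NO)c1ccc(CN2C(=O)/C(=C3\Nc4ccccc4\C3=N/O)c3cc(Cl)ccc32)cc1` gives 16 nM.
Compound 2 `O=C(NO)c1ccc(CN2C(=O)/C(=C3\Nc4ccccc4\C3=N/O)c3cc(F)ccc32)cc1` gives 43 nM.
Compound 3 `Cc1ccc2c(c1)/C(=C1/Nc3ccccc3/C1=N\O)C(=O)N2Cc1ccc(C(=O)NO)cc1` gives 20 nM.

Compound 3 stands second highest of these three numbers. Its nearest neighbour is compound 1: the step of a 1.3-fold higher number from compound 1 to compound 3 (0.10 log units; within the scatter) lies within the scatter, so the two cannot be told apart. Its furthest neighbour is compound 2: the step of a 2.2-fold lower number from compound 2 to compound 3 (0.33 log units; beyond the scatter) lies beyond the scatter, a modest difference.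

Compound 4 `O=C(NO)c1ccc(CN2C(=O)/C(=C3\Nc4ccccc4\C3=N/O)c3cc(Br)ccc32)cc1` is not yet measured. It differs from compound 3 by bromo in place of methyl on an aromatic carbon. Going by the values given here, two measured steps bear on this. Swapping chloro for methyl at this position, a 1.3-fold higher number from compound 1 to compound 3 (0.10 log units; within the scatter), changed little, whereas swapping chloro for fluoro, a 2.7-fold higher number from compound 1 to compound 2 (0.43 log units; beyond the scatter), weakened inhibition modestly. Bromo, like chloro, is a heavier halogen, so the expected step of a 1.3-fold lower number from compound 3 to compound 4 (0.12 log units; within the scatter) in this assay is small, if anything slightly toward a lower number, and probably within the scatter. Compound 4 is therefore estimated at 15 nM, with a range from 6 nM to 40 nM.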

Compound 4, half-maximal inhibitory concentration: 24 nM
Estimate against measurement, compound 4: 1.6-fold (0.20 log units) below, within the range that was stated.
By their numbers in this assay, from the lowest: compounds 1, 3, 4 and 2 (each within the scatter of the next, the first and the last beyond it).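

In this assay, bromo at this position cannot be told apart from any of the other three groups: a 1.2-fold higher number from compound 3 to compound 4 (0.08 log units; within the scatter) and a 1.5-fold higher number from compound 1 to compound 4 (0.18 log units; within the scatter) and a 1.8-fold lower number from compound 2 to compound 4 (0.25 log units; within the scatter) all stay within the scatter. Methyl, chloro and bromo are therefore interchangeable here on this read-out, and compound 2 with fluoro, though beyond the scatter of compound 1 and compound 3, is not separated from compound 4. No measured evidence bears on this result.

The compounds shown carry only methyl and halogens at this position, so it remains open whether a different kind of group, such as an amine, a carboxylic acid or a methoxy, would move the number beyond the scatter. On these data alone, whether the same swaps would behave alike on another carbon of this ring also remains open.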